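The compounds below may be only part of what the source reports. "The series", "measured", "known", "first", "only" and "open" are said of these compounds alone.

Compound 1 `SC1=NC(n2nc(-c3ccccc3)nc2-c2ccccc2)=CC(c2ccc(Cl)cc2)N1` and compound 2 `CN(C)c1ccc(C2C=C(n3cc(-c4ccccc4)nc3-c3ccccc3)N=C(S)N2)cc1` were both tested in a functional assay on the whole organism with Mus musculus as the target, in the maximal electroshock model, with a stated time of 0.5 h; a higher number here means that more compound is needed for the effect, a lower number that less compound is needed. Compound 1 gives 30 mg/kg, the lowest of the two numbers, while compound 2 gives 100 mg/kg, a gap that lies beyond the usual scatter. Compound 3 `Oc1ccc(C2C=C(n3nc(-c4ccccc4)nc3-c3ccccc3)N=C(S)N2)cc1` has not yet been measured in this assay.

Compound 3 differs from compound 1 by hydroxy in place of chloro on an aromatic carbon. Within the data shown here, no pair of measured compounds isolates this single change, so no direct precedent sets the size of the step. Among the measured compounds shown here, the only other measured compound, compound 2, differs from compound 1 in more than one place, and its higher number offers at most a faint hint that changes in this part of the molecule raise the dose needed.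

For compound 3 the step of a 2.0-fold higher number from compound 1 to compound 3 (0.30 log units; within the scatter) is expected to be a modest rise, close to the edge of the scatter. Compound 3 is therefore estimated at 60 mg/kg, with a range from 20 mg/kg to 200 mg/kg.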

Compound 3, minimum effective dose: 30 mg/kg
Beside the measured number, compound 3's estimate is 2.0-fold (0.30 log units) above it; the range from low to high includes it.
By their numbers in this assay, from the lowest: compounds 1 and 3 (each within the scatter of the next); then compound 2.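

In this assay, among these compounds, replacing 4-chlorophenyl with 4-hydroxyphenyl brings no change at the digits printed from compound 1 to compound 3 (within the scatter), and this is the first direct reading of this single change. At this place on the aromatic ring, para to a large group, chloro can therefore give way to hydroxy, a group counted as both a hydrogen-bond donor and acceptor, with no shift beyond the scatter in the dose needed. No measurement at hand speaks to what lies behind this result.

Going by these compounds, whether this holds for other groups at the same place stays open, since a methoxy group, a carboxylic acid or a longer chain might give a different number. On these data alone, it is also open whether hydroxy in place of chloro would give the same result on a different core.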